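Swapping a Bromophenyl for Thiophene in a Thromboxane Synthase Inhibitor

The source may hold more compounds than are shown below. What is called first, only, known or untested is meant among the compounds shown, and "the series" means these compounds.

Compound 1, `O=C(O)CCCC/C=C(/c1ccc(Br)cc1)c1cccnc1`, is a chain acid that carries a pyridine and a 4-bromophenyl group on its double bond. In an assay (Equus caballus) for inhibition of Thromboxane-A synthase (Homo sapiens), using microsomes (on this read-out lower numbers stand for stronger inhibition and higher numbers for weaker inhibition), compound 1 gives 82 nM. Among the three compounds that have been measured, compound 1 stands second highest on this read-out. Compound 2, `O=C(O)C(CCC/C=C(\c1ccccc1)c1cccnc1)Sc1ccccc1`, gives 33 nM in this assay, a lower number and therefore stronger inhibition, with the gap to compound 1 lying beyond the usual scatter. Compound 3, `NC(=O)CCCC/C=C(\c1ccccc1)c1cccnc1`, gives 400 nM in this assay, a higher number and weaker inhibition, again beyond the scatter.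

Compound 4, `O=C(O)CCCC/C=C(\c1cccnc1)c1cccs1`, has not yet been measured in this assay. It differs from compound 1 in one place only: thiophen-2-yl in place of 4-bromophenyl on a double-bonded chain carbon bound to an aromatic carbon and a double-bonded chain carbon. The pyridine, the chain and the acid are kept. Going by the values given here, no measured pair in this set shows how such a ring swap moves the number, so the expectation rests on compound 1 and on the small size of the change. An aromatic ring stays at the same place, and the step from compound 1 to compound 4 is expected to be a 1.2-fold higher number from compound 1 to compound 4 (0.09 log units; within the scatter), most likely within the scatter. Compound 4 is therefore estimated at 100 nM, with a range from 40 nM to 250 nM.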

Compound 4, half-maximal inhibitory concentration: 20 nM
For compound 4 the middle estimate is 5.0-fold (0.70 log units) above the measured one; the measured number lies below the stated range.
By their numbers in this assay, from the lowest: compounds 4 and 2 (each within the scatter of the next); then compound 1; then compound 3.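

At this place, on a double-bonded chain carbon bound to an aromatic carbon and a double-bonded chain carbon, the choice of aromatic ring clearly matters: in this assay, thiophen-2-yl in place of 4-bromophenyl gives a 4.1-fold lower number from compound 1 to compound 4 (0.61 log units; beyond the scatter) with the pyridine, the chain and the acid all kept. Going by these compounds alone, this is the first change at a single place in the set, and it shows that a five-membered aromatic ring with 1 hetero atom is accepted here and gives stronger inhibition than the 4-bromophenyl ring, a shift that lies beyond the usual scatter. No measurement shown here explains why the number falls, so the step stands as an observation only.

Two things change together in this swap, the ring and the bromine, and the compounds shown do not separate them, since no other compound shares this chain acid with a different ring at this place. Rings such as thiophen-3-yl or furan-2-yl at the same place would help show whether the gain depends on the sulfur atom, on where the ring is attached, or simply on losing the 4-bromophenyl group.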